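A few compounds are considered here, and "the series" means these few. Any claim that something is new, unique, unknown or untested is made for them only; others in the source may bear on it.

For the measured compounds named here, compound 2 `CC(C)(C)[C@H](N)CN(C(=O)[C@@H]1C[C@H]1c1ccccc1)c1ccc(-c2ccccc2)cc1` is the upper of the two numbers measured so far: in a functional assay for agonist activity at G protein-coupled receptor 88 (Homo sapiens), read by HTRF and cAMP accumulation (a higher number here means that more compound is needed for the effect, a lower number that less compound is needed), compound 2 gives 11 nM, whereas compound 1 `CC(C)[C@H](N)CN(C(=O)[C@@H]1C[C@H]1c1ccccc1)c1ccc(-c2ccccc2)cc1` gives 1.1 nM. Going by the values given here, the one step recorded between them, a 10-fold higher number from compound 1 to compound 2 (1.00 log units; beyond the scatter), is the only guide available. The next compound, compound 3 `CC(C)C[C@H](N)CCN(C(=O)[C@@H]1C[C@H]1c1ccccc1)c1ccc(-c2ccccc2)cc1`, differs from compound 2 by 2-amino-4-methylpentyl in place of 1-amino-2,2-dimethylpropyl on a saturated chain carbon bound to an amide-type nitrogen, so the chain carrying the amine is lengthened by one member and its branching is changed at the same time. Among the compounds with values here, no recorded step covers this change directly; the step from compound 1 to compound 2 concerns only the added methyl on the branch carbon, and the lengthening of the chain has no precedent here. The change therefore cannot be sized from the data, and the expectation is a step of a 1.1-fold higher number from compound 2 to compound 3 (0.04 log units; within the scatter) from compound 2 to compound 3, with a wide uncertainty. On that basis compound 3 is estimated at 12 nM in this assay, within a range of 1.5 nM to 100 nM.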

Compound 3, half-maximal effective concentration: 3 nM
Estimate against measurement, compound 3: 4.0-fold (0.60 log units) above; measured number inside the range.
By their numbers in this assay, from the lowest: compound 1; then compound 3; then compound 2.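

In this assay, the place on a saturated chain carbon bound to an amide-type nitrogen accepts a larger change than the added methyl of the earlier step, and the number does not have to rise: 2-amino-4-methylpentyl in place of 1-amino-2,2-dimethylpropyl gives a 3.7-fold lower number from compound 2 to compound 3 (0.56 log units; beyond the scatter). The same group in place of 1-amino-2-methylpropyl gives a 2.7-fold higher number from compound 1 to compound 3 (0.44 log units; beyond the scatter), so compound 1 keeps the lowest number of the three while compound 3 recovers part of the rise seen with compound 2. No information is available to explain either step.

Each of these steps alters the chain and its branching together, so the contribution of each cannot be separated; 1-amino-3-methylbutyl, which keeps the shorter chain, and 2-amino-3-methylbutyl, which keeps the branching of compound 1 on the longer chain, would divide the change. Also open, on these data alone, is whether the amine itself is needed at this place, a question that a hydroxyl group in its stead would address.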